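Pyridin-4-yl for Pyridin-3-yl: Expected Cytotoxicity of Compound 4

The compounds below may be only part of what the source reports. "The series", "measured", "known", "first", "only" and "open" are said of these compounds alone.

Compound 1 `Cn1cc(C2CC(c3ccccc3)=NN2C(=O)c2cccnc2)c2ccccc21` and compound 2 `Cn1cc(C2CC(c3ccccc3)=NN2C(=O)c2ccncc2)c2ccccc21` share one core and differ in a single place: pyridin-4-yl in place of pyridin-3-yl on a carbonyl carbon. In an ADME assay on HEK-293T cells (Homo sapiens) for cytotoxicity, read by MTT assay, with a stated time of 48 h (on this read-out higher numbers stand for lower toxicity in this test and lower numbers for higher toxicity in this test), compound 1 gives only a limit of the assay, > 300000 nM. In this assay compound 2 gives 97300 nM. That change therefore brought an at least 3.0-fold lower number from compound 1 to compound 2 (0.48 log units; beyond the scatter).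

Compound 3 `COc1ccc(C2=NN(C(=O)c3cccnc3)C(c3cn(C)c4ccc(Br)cc34)C2)cc1OC` is built on another core; how the two cores differ is not broken down here. In this assay compound 3 also gives only a limit, > 300000 nM.

Compound 4 `COc1ccc(C2=NN(C(=O)c3ccncc3)C(c3cn(C)c4ccc(Br)cc34)C2)cc1OC` has not yet been measured and differs from compound 3 by the same change made in the same place: pyridin-4-yl in place of pyridin-3-yl on a carbonyl carbon. Because of the limit of > 300000 nM in this assay, at which 2 of the 3 values shown sit, the starting point of compound 3 is known only as a limit, so the size of the coming step can only be carried over. The expected step, resting on the measured step of an at least 3.0-fold lower number from compound 1 to compound 2 (0.48 log units; beyond the scatter), is an at least 2.5-fold lower number from compound 3 to compound 4 (0.39 log units; beyond the scatter). Compound 4 is thus estimated to give about 120000 nM in this assay, expected to lie between 40000 nM and 300000 nM.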

Compound 4, half-maximal cytotoxic concentration: > 300000 nM
Compound 4: only a limit was reported (the forecaster's own chance of this, stated with the estimate: 30%); at least 2.5-fold (0.39 log units) between middle value and limit.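

In this assay compound 3 and compound 4 both give only a limit of the assay, so no step between the two can be read: the limit of > 300000 nM in this assay, at which 3 of the 4 values shown sit.

The compounds shown leave open whether pyridin-4-yl in place of pyridin-3-yl on a carbonyl carbon changes the number at all on the core of compound 3.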